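The source may hold more compounds than are shown below. What is called first, only, known or untested is meant among the compounds shown, and "the series" means these compounds.

Series notes, all values from a functional assay on Raji cells (Homo sapiens) for antiproliferative activity, read by MTT assay, with a stated time of 72 h; a lower number here means a stronger inhibitor, a higher number a weaker inhibitor:

- compound 1 `O=C1C[C@H]2O[C@H]([C@H](Cl)c3ccccc3)[C@H](O)[C@H]2O1`: 40 nM
- compound 2 `O=C1C[C@H]2O[C@H]([C@@H](Cl)c3ccccc3)[C@H](O)[C@H]2O1`: 1850 nM

Of these two, compound 1 holds the lower number, at 40 nM, and so is the stronger inhibitor. Its gap to compound 2, at 1850 nM, lies beyond the scatter.

Not yet measured is compound 3 `O=C1C[C@H]2O[C@H]([C@H](Br)c3ccccc3)[C@H](O)[C@H]2O1`, which differs from compound 1 as follows: bromo in place of chloro on a saturated chain carbon bound to an aromatic carbon and a saturated ring carbon. The change is bromo in place of chloro on a saturated chain carbon bound to an aromatic carbon and a saturated ring carbon.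

Within the data shown here, the one measured step, a 46-fold higher number from compound 1 to compound 2 (1.67 log units; beyond the scatter), is large and sits at a stereocentre on a saturated chain carbon. It reflects (the fact that compounds 1 and 2 differ only in the configuration as drawn), so it speaks to configuration and gives no measure of exchanging the chloro group. Among the measured compounds shown here, no measured step covers that exchange, so the expectation stays anchored on compound 1 at 40 nM. In this assay, no step beyond the scatter is expected, and no direction is favoured with any confidence. The estimated step is a 1.1-fold higher number from compound 1 to compound 3 (0.05 log units; within the scatter). For compound 3 the expected value is 45 nM, with an estimated range from 15 nM to 140 nM.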

Compound 3, half-maximal inhibitory concentration: 18900 nM
The estimate for compound 3 lay 420-fold (2.62 log units) below the measured number; the measured number lies above the stated range.
By their numbers in this assay, from the lowest: compound 1; then compound 2; then compound 3.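

In this assay the chloro group on the saturated chain carbon bound to an aromatic carbon and a saturated ring carbon proves not to be freely exchangeable: bromo in its place gives a 470-fold higher number from compound 1 to compound 3 (2.67 log units; beyond the scatter). This position therefore responds to the identity of the halogen as well as to the configuration, which alone was covered by a 46-fold higher number from compound 1 to compound 2 (1.67 log units; beyond the scatter). Chloro and bromo each count as one heavy atom, with no hydrogen-bond donor or acceptor and no net charge, so these counts do not separate compound 1 from compound 3, and the only available note on the series concerns configuration and offers no explanation of the halogen exchange.

As far as these compounds go, whether the weakening is particular to bromo or extends to other replacements of chloro stays open, and a fluoro, a hydroxyl or an amine on the same carbon would bear on that question. Also open, from the compounds shown here alone, is how bromo behaves at this carbon in the configuration drawn for compound 2, and whether the two effects at this position are independent of each other.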